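Biphenyl for bromine on a thioacetate oxazoline core

A few compounds are considered here, and "the series" means these few. Any claim that something is new, unique, unknown or untested is made for them only; others in the source may bear on it.

Compound 2 `C=C[C@@H]1OC(c2ccc(Br)cc2)=N[C@H]1CO` was tested in an assay on isolated protein for inhibition of matrix metalloproteinase-9 (Homo sapiens) (on this read-out higher numbers stand for weaker inhibition and lower numbers for stronger inhibition), where compound 2 gives 9000 nM. Compound 1 `C=C[C@@H]1OC(c2ccc(-c3ccccc3)cc2)=N[C@H]1CO` shares its core and differs by phenyl in place of bromo on an aromatic carbon; in this assay compound 1 gives 24000 nM, a step of a 2.7-fold higher number from compound 2 to compound 1 (0.43 log units; beyond the scatter). Compound 3 `C=C[C@@H]1OC(c2ccc(Br)cc2)=N[C@H]1SC(C)=O` carries a different core, differing from compound 2 by acetylsulfanyl in place of hydroxymethyl on a saturated ring carbon; in this assay compound 3 gives 88000 nM, the highest number of the three, a step of a 9.8-fold higher number from compound 2 to compound 3 (0.99 log units; beyond the scatter).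

Compound 4 `C=C[C@@H]1OC(c2ccc(-c3ccccc3)cc2)=N[C@H]1SC(C)=O` has not yet been measured. It differs from compound 3 by phenyl in place of bromo on an aromatic carbon. Among the compounds with values here, this is the same kind of change as the one from compound 2 to compound 1, though the place is described differently: there the phenyl stands para to a group of 9 heavy atoms, here para to a large group. Resting on the step of a 2.7-fold higher number from compound 2 to compound 1 (0.43 log units; beyond the scatter), the expected step from compound 3 to compound 4 in this assay is estimated at a 2.5-fold higher number from compound 3 to compound 4 (0.40 log units; beyond the scatter). Compound 4 is therefore expected to give about 220000 nM, estimated between 70000 nM and 700000 nM.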

Compound 4, inhibition constant: 81000 nM
Compound 4: middle estimate off by 2.7-fold (0.43 log units), on the high side; the range from low to high includes it.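

On the core of compound 3, phenyl in place of bromo gives a 1.1-fold lower number from compound 3 to compound 4 (0.04 log units; within the scatter) in this assay, so the higher number seen on the core of compound 2 does not carry over to this core: the same change on two cores in this assay, a 2.7-fold higher number (0.43 log units; beyond the scatter) from compound 2 to compound 1 and a 1.1-fold lower number (0.04 log units; within the scatter) from compound 3 to compound 4, 2.9-fold (0.46 log units) apart, beyond the scatter of two such steps. Acetylsulfanyl in place of hydroxymethyl raises the number with either group on the aromatic carbon, but with phenyl the step, a 3.4-fold higher number from compound 1 to compound 4 (0.53 log units; beyond the scatter), is smaller than with bromo: the same change on two cores in this assay, a 9.8-fold higher number (0.99 log units; beyond the scatter) from compound 2 to compound 3 and a 3.4-fold higher number (0.53 log units; beyond the scatter) from compound 1 to compound 4, 2.9-fold (0.46 log units) apart, beyond the scatter of two such steps. These comparisons show that, in this set of four compounds, the size of each step depends on the other place, but they rest on a single pair of cores and do not show why the steps differ or how the change would behave on any further core.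

The compounds shown leave open whether phenyl in place of bromo on other cores would follow the step from compound 2 or the one from compound 3. They also leave open what a thiol, an amine or a carboxylic acid would give in place of acetylsulfanyl on the saturated ring carbon.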